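This account rests on a few compounds, and the source may have more. Where it says the series, first, only, none or still open, it means among the compounds named here.

Two members of the series have so far been run in a functional assay on Hs-578T cells (Homo sapiens) for cytotoxicity, read by luminescence and CellTiter-Glo, with a stated time of 24 h; a lower number here means a stronger inhibitor, a higher number a weaker inhibitor. Compound 1 `C=C1C[C@]23C[C@@]1(O)CC[C@H]2c1cc2c(C(=O)O)coc2c(C)c1[C@@H]3C(=O)O` gives > 10000 nM, a limit of the assay rather than a number. Compound 2 `C=C1C[C@]23C[C@@]1(O)CC[C@H]2c1cc(Br)c(O/C=C/C(=O)OC)c(C)c1[C@@H]3C(=O)OC` likewise gives > 10000 nM, again only a limit. For the measured compounds named here, both readings sit at the limit of > 10000 nM in this assay, at which 2 of the 2 values shown sit, so no measured step between them can be sized and compound 2 stands simply at the limit. Compound 3 `C=C1C[C@]23C[C@@]1(O)CC[C@H]2c1ccc(O/C=C/C(=O)OC)c(C)c1[C@@H]3C(=O)OC` differs from compound 2 by hydrogen in place of bromo on an aromatic carbon. With both neighbours at the limit, the change is expected to move little, if at all: a step that the limit leaves unreadable from compound 2 to compound 3. Compound 3 is therefore estimated at 15000 nM, with a range of 5000 nM to 50000 nM, and will most likely again be reported only as a limit.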

Compound 3, half-maximal inhibitory concentration: > 10000 nM
Compound 3 gave a limit, no number (the forecaster's own chance of this, stated with the estimate: 75%); the middle value is on the limit's open side.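

Compound 2 and compound 3 are both only limits in this assay, so no step can be read between them: the limit of > 10000 nM in this assay, at which 3 of the 3 values shown sit.

The compounds shown leave open whether any change to the shared core gives a measurable number in this assay.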